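From 2,4-Difluorophenyl to 4-Acetylphenyl in a Flat Series

The source may hold more compounds than are shown below. What is called first, only, known or untested is meant among the compounds shown, and "the series" means these compounds.

In a functional assay on HCT-116 cells (Homo sapiens) for antiproliferative activity, read by MTT assay, with a stated time of 72 h (a higher number here means a weaker inhibitor, a lower number a stronger inhibitor), compound 1 (`Cc1ccc(N2CCN(C(=S)SCc3ccc4nc(N)nc(N)c4c3)CC2)cc1`) gives 5510 nM while compound 2 (`Nc1nc(N)c2cc(CSC(=S)N3CCN(c4ccc(F)cc4)CC3)ccc2n1`) gives 3270 nM and compound 3 (`Nc1nc(N)c2cc(CSC(=S)N3CCN(c4ccc(F)cc4F)CC3)ccc2n1`) gives 5150 nM on the same scale. Compound 3 cannot be told apart from the other two: the measured steps are a 1.1-fold lower number from compound 1 to compound 3 (0.03 log units; within the scatter) and a 1.6-fold higher number from compound 2 to compound 3 (0.20 log units; within the scatter) and neither is a real difference.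

The next compound, compound 4 (`CC(=O)c1ccc(N2CCN(C(=S)SCc3ccc4nc(N)nc(N)c4c3)CC2)cc1`), has not yet been measured. Compared with compound 3 it carries 4-acetylphenyl in place of 2,4-difluorophenyl on an amine nitrogen in a ring and neither group has a net charge.

The closest evidence comes from earlier changes on that same aromatic ring. These are a 1.7-fold lower number from compound 1 to compound 2 (0.23 log units; within the scatter) and again a 1.6-fold higher number from compound 2 to compound 3 (0.20 log units; within the scatter) and both stay small. Within the data shown here, no measured compound carries an acetyl group, so this evidence reaches only partway and the range must stay wide. Even so, nothing measured points to a step beyond the scatter in either direction. In this assay the estimated change is a 1.1-fold lower number from compound 3 to compound 4 (0.06 log units; within the scatter) and that is expected to stay within the scatter. For compound 4 the expected value is 4500 nM with an estimated range of 2000 nM to 10000 nM as the likely span.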

Compound 4, half-maximal inhibitory concentration: 8260 nM
Compound 4: the middle estimate sits 1.8-fold (0.26 log units) below what was measured, within the range that was stated.
By their numbers in this assay, from the lowest: compounds 2, 3, 1 and 4 (each within the scatter of the next, the first and the last beyond it).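

On the aromatic ring carried by the amine nitrogen of the six-membered ring, acetyl gives the only step among these compounds that lies beyond the scatter in this assay (a 2.5-fold higher number from compound 2 to compound 4 (0.40 log units; beyond the scatter)), and that step is modest. This does not make compound 4 distinct from every other compound, since the steps from the other two compounds stay within the scatter (a 1.6-fold higher number from compound 3 to compound 4 (0.21 log units; within the scatter); a 1.5-fold higher number from compound 1 to compound 4 (0.18 log units; within the scatter)), so the change can be read only against the fluoro group of compound 2. The 4-acetylphenyl group brings one hydrogen-bond acceptor and one double bond outside aromatic rings, which 2,4-difluorophenyl does not have, but no evidence is available to connect either feature with the result or to explain it.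

The compounds shown leave open how a plain phenyl ring, or an aromatic ring carrying an amine or a carboxylic acid in place of the acetyl group, would read on this scale. They also leave open whether the step seen with acetyl would carry over to a longer chain on the carbonyl, such as propanoyl in place of acetyl.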